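Methyl to methoxy on the sulfonamide aromatic ring

A few compounds are considered here, and "the series" means these few. Any claim that something is new, unique, unknown or untested is made for them only; others in the source may bear on it.

In a functional assay on MCF7 cells (Homo sapiens) for antiproliferative activity, read by sulforhodamine B assay, with a stated time of 48 h (on this read-out higher numbers stand for weaker inhibition and lower numbers for stronger inhibition), compound 1 (`O=C1NCCN1c1ccc(S(=O)(=O)Nc2cccc(Br)c2)cc1`) gives 100 nM. Compound 3 (`Cc1ccccc1NS(=O)(=O)c1ccc(N2CCNC2=O)cc1`) gives 280 nM, the higher of the two exact numbers. Compound 2 (`COc1ccc(NS(=O)(=O)c2ccc(N3CCNC3=O)cc2)cc1`) reads > 1000 nM, which is a limit of the assay.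

Compound 4 (`COc1ccccc1NS(=O)(=O)c1ccc(N2CCNC2=O)cc1`) carries methoxy in place of methyl on an aromatic carbon, ortho to a large group: methoxy in place of methyl on an aromatic carbon.

The closest evidence is an at least 3.5-fold lower number from compound 2 to compound 3 (0.55 log units; beyond the scatter), where 2-methylphenyl replaces 4-methoxyphenyl. The other relevant step is a 2.8-fold higher number from compound 1 to compound 3 (0.45 log units; beyond the scatter). Neither step tests 2-methoxyphenyl directly, so only a modest rise in this assay is expected. The estimated change is a 2.1-fold higher number from compound 3 to compound 4 (0.33 log units; beyond the scatter). For compound 4, the expected value is 600 nM, with an estimated range of 200 nM to 1800 nM.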

Compound 4, half-maximal inhibitory concentration: 770 nM
Beside the measured number, compound 4's estimate is 1.3-fold (0.11 log units) below it; the measured number falls inside the stated range.
By their numbers in this assay, from the lowest: compound 1; then compound 3; then compound 4. At a limit, above all of these: compound 2.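

In this assay, methoxy in place of methyl on an aromatic carbon, ortho to a large group, weakens inhibition: a 2.8-fold higher number from compound 3 to compound 4 (0.44 log units; beyond the scatter). The 2-methoxyphenyl group also falls well short of the 3-bromophenyl group: a 7.7-fold higher number from compound 1 to compound 4 (0.89 log units; beyond the scatter). The comparison of the two methoxyphenyl groups yields only a limit, an at least 1.2-fold lower number from compound 2 to compound 4 (0.11 log units; that floor lies within the scatter), and so orders neither: the limit of > 1000 nM in this assay, at which 1 of the 4 values shown sits.

The compounds shown leave open how a hydroxyl, an amine or an ethyl group would read at this place on the ring.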